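Cinnamate glycolamide esters: freeing the aromatic hydroxy

The source may hold more compounds than are shown below. What is called first, only, known or untested is meant among the compounds shown, and "the series" means these compounds.

Compound 1 `COCOc1cc(/C=C/C(=O)OCC(=O)Nc2ccc(OC)cc2)ccc1OCc1ccccc1` carries a methoxymethyl ether on its aromatic oxygen. In a functional assay on CNE cells (Homo sapiens) for cytotoxicity, read by MTT assay, with a stated time of 72 h (a higher number here means a weaker inhibitor, a lower number a stronger inhibitor), compound 1 gives only a limit, > 200000 nM. Compound 2 `COCOc1cc(/C=C/C(=O)OCC(=O)Nc2ccc(Cl)cc2)ccc1OCc1ccccc1` differs by chloro in place of methoxy on an aromatic carbon. In this assay compound 2 likewise gives only a limit, > 200000 nM. Compound 3 `COCOc1cc(/C=C/C(=O)OCC(=O)NN2CCOCC2)ccc1OCc1ccccc1` carries morpholin-4-yl in place of 4-methoxyphenyl on the amide-type nitrogen. In this assay compound 3 also gives only a limit, > 200000 nM. All three values sit at the limit of > 200000 nM in this assay, at which 3 of the 3 values shown sit, so the steps a step that the two limits leave unreadable from compound 1 to compound 2, a step that the two limits leave unreadable from compound 1 to compound 3 and a step that the two limits leave unreadable from compound 2 to compound 3 cannot be read in size or direction; compound 1 stands at the limit like the rest of the set.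

Compound 4 `COc1ccc(NC(=O)COC(=O)/C=C/c2ccc(OCc3ccccc3)c(O)c2)cc1` differs from compound 1 by hydrogen in place of methoxymethyl on an oxygen on an aromatic ring, leaving a hydroxy on the aromatic oxygen. Among the measured compounds shown here, none of the measured steps touches this oxygen; all of them vary the amide end, and none is readable. For the measured compounds named here, the step to compound 4 therefore has no measured precedent, and the limit for compound 1 is the only anchor. Compound 4 is expected to stay near that limit, and the step of an at least 1.3-fold lower number from compound 1 to compound 4 (0.12 log units; that floor lies within the scatter) is expected to be small or not readable. Compound 4 is thus estimated at 150000 nM, within 40000 nM to 400000 nM.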

Compound 4, half-maximal inhibitory concentration: > 200000 nM
Compound 4 was reported as a limit; the forecaster's own chance of this, stated with the estimate: 65%; middle value at least 1.3-fold (0.12 log units) from the limit.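

In this assay compound 4 gives > 200000 nM, which is a limit. Compound 1 is also reported only as a limit, so no new step can be read between compound 1 and compound 4, in size or direction: the limit of > 200000 nM in this assay, at which 4 of the 4 values shown sit.

The compounds shown leave open whether hydrogen in place of methoxymethyl, or any change at the amide end, alters the value at all.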